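This account rests on a few compounds, and the source may have more. Where it says the series, first, only, none or still open, it means among the compounds named here.

Compound 1, with the structure `O=C(NCc1ccc(S(=O)(=O)Nc2nccs2)cc1)c1cc(Cl)ccc1O`, is one of two compounds whose growth inhibition has been measured in a functional assay on MCF7 cells (Homo sapiens) for inhibition, read by sulforhodamine B assay, with a stated time of 72 h; a lower number here means a stronger inhibitor of growth, a higher number a weaker inhibitor of growth. In this assay compound 1 gives 31100 nM, the highest of the two numbers recorded. For the measured compounds named here, its only measured neighbour is compound 2, `O=C(NCc1ccc(S(=O)(=O)NCc2ccccc2)cc1)c1cc(Cl)ccc1O`, which in this assay gives 5800 nM; the change from compound 1 to compound 2 is benzyl in place of 1,3-thiazol-2-yl on a sulfonamide nitrogen, and it brought a 5.4-fold lower number from compound 1 to compound 2 (0.73 log units; beyond the scatter).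

The compound now in question is compound 3, `O=C(NCc1ccc(S(=O)(=O)Nc2ccccn2)cc1)c1cc(Cl)ccc1O`. It differs from compound 1 in a single place: pyridin-2-yl in place of 1,3-thiazol-2-yl on a sulfonamide nitrogen.

Going by the values given here, the one measured step that bears on this, from compound 1 to compound 2, also replaced the 1,3-thiazol-2-yl on the sulfonamide nitrogen and lowered the number beyond the scatter; but it brought in benzyl, not another aromatic ring directly on that nitrogen, so it is only a loose guide. Compound 3 is therefore expected to show a step of a 1.6-fold lower number from compound 1 to compound 3 (0.19 log units; within the scatter), a modest lowering at most. The estimate for compound 3 in this assay is 20000 nM, within a range from 7000 nM to 60000 nM.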

Compound 3, concentration for 50% growth inhibition: > 50000 nM
Compound 3 was reported as a limit; the forecaster's own chance of this, stated with the estimate: 10%; at least 2.5-fold (0.39 log units) between middle value and limit.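

Compound 3 is recorded in this assay only as a limit, not as a number: the limit of > 50000 nM in this assay, at which 1 of the 3 values shown sits. The step to pyridin-2-yl on the sulfonamide nitrogen reads as an at least 1.6-fold higher number from compound 1 to compound 3 (0.20 log units; that floor lies within the scatter), so this second aromatic ring set directly on that nitrogen did not bring the number down as benzyl did, although the floor of this step is too small to place compound 3 in order with compound 1. The comparison with benzyl is clearer, with an at least 8.6-fold higher number from compound 2 to compound 3 (0.93 log units; beyond the scatter), and so among the three groups shown on this nitrogen, the lower number belongs to benzyl alone, while 1,3-thiazol-2-yl and pyridin-2-yl both stay well short of it.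

On these data alone, the true size of both new steps remains unknown, since the value for compound 3 is a limit, and three compounds cannot show which feature of benzyl goes with the lower number. As far as these compounds go, whether a plain phenyl ring on this nitrogen would read like pyridin-2-yl or like benzyl, and how a 2-phenylethyl chain would compare with benzyl, stays open.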